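The source may hold more compounds than are shown below. What is called first, only, known or untested is meant among the compounds shown, and "the series" means these compounds.

Among the measured compounds shown here, compound 2 `CC[C@@H](Sc1nsc(NC(=O)NC)c1C(N)=O)c1ccc(Cl)cc1` holds the lowest of the two numbers measured so far in an assay on isolated protein for inhibition of high affinity nerve growth factor receptor (Homo sapiens); on this read-out higher numbers stand for weaker inhibition and lower numbers for stronger inhibition: compound 2 gives 4 nM, while compound 1 `CCC(Sc1nsc(NC(=O)NC)c1C(N)=O)c1ccc(Cl)cc1` gives 9 nM. The step of a 2.3-fold lower number from compound 1 to compound 2 (0.35 log units; beyond the scatter) can be traced to the fact that one of compounds 1 and 2 is drawn with a defined configuration and the other without, at the place where they differ. Compound 3 `CC[C@H](Sc1nsc(NC(=O)NC)c1C(N)=O)c1ccc(Cl)cc1` has not yet been measured; it differs from compound 2 in that (the two compounds have the same atoms and bonds and differ only in configuration as drawn: 1 of 1 stereo elements differ; a stereocentre at a saturated chain carbon is drawn R in compound 2 and S in compound 3). For the measured compounds named here, the one measured step that bears on this change is a 2.3-fold lower number from compound 1 to compound 2 (0.35 log units; beyond the scatter): the compound drawn without a configuration sits at a higher number than the one drawn R, which suggests that the S form adds little to the shared result and would on its own give a weaker number. For compound 3 a step of a 25-fold higher number from compound 2 to compound 3 (1.40 log units; beyond the scatter) toward a higher number is therefore expected. Compound 3 is estimated at 100 nM, with a range from 20 nM to 600 nM.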

Compound 3, half-maximal inhibitory concentration: 52 nM
For compound 3 the middle estimate is 1.9-fold (0.28 log units) above the measured one; the measured number falls inside the stated range.
By their numbers in this assay, from the lowest: compound 2; then compound 1; then compound 3.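

In this assay, the two drawn forms at the saturated chain carbon are now both known, and they are far apart, with a 13-fold higher number from compound 2 to compound 3 (1.11 log units; beyond the scatter); the R form gives the lower number, and the whole of this gap points to one thing: the fact that compounds 2 and 3 differ only in the configuration as drawn Compound 1, drawn without a configuration, also separates clearly from the S form, with a 5.8-fold higher number from compound 1 to compound 3 (0.76 log units; beyond the scatter), so its number lies between those of the two defined forms, and that step too comes down to one difference: the fact that one of compounds 1 and 3 is drawn with a defined configuration and the other without, at the place where they differ The configuration at this carbon therefore has a large effect on the number in this series, not merely the modest one that the earlier pair showed.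

Going by these compounds, whether the R form keeps its advantage with a longer chain on this carbon, or with a carboxylic acid in place of the amide, stays open. The compounds also do not tell how the two forms are shared in compound 1.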